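A few compounds are considered here, and "the series" means these few. Any claim that something is new, unique, unknown or untested is made for them only; others in the source may bear on it.

Measured compounds:
- compound 1, `Cc1ccccc1-c1cccc(COc2ccc(S(=O)(=O)CC(=O)O)cc2)c1`: 46.8 nM
- compound 2, `O=C(O)CS(=O)(=O)c1ccc(OCc2cccc(-c3ccccc3)c2)cc1`: 288 nM
- compound 3, `O=C(O)CS(=O)(=O)c1ccc(OCc2cccc(-c3ccccc3F)c2)cc1`: 257 nM

In a functional assay on CHO cells for agonist activity at Free fatty acid receptor 1 (Homo sapiens), read by FLIPR and calcium flux (a higher number here means that more compound is needed for the effect, a lower number that less compound is needed), compound 3 gives 257 nM, the second highest of the three numbers; compound 2 and compound 3 lie within the scatter of each other (a 1.1-fold lower number from compound 2 to compound 3 (0.05 log units; within the scatter)), while compound 1 needs clearly less compound (a 5.5-fold higher number from compound 1 to compound 3 (0.74 log units; beyond the scatter)). Compound 4, `O=C(O)CS(=O)(=O)c1ccc(OCc2cccc(-c3ccccc3C(F)(F)F)c2)cc1`, is made from compound 3 by trifluoromethyl in place of fluoro on an aromatic carbon. For the measured compounds named here, no measured step swaps fluoro for trifluoromethyl. The nearest guide is methyl in place of fluoro, which in this assay gave a 5.5-fold higher number from compound 1 to compound 3 (0.74 log units; beyond the scatter) read backwards, whereas hydrogen against fluoro made no difference beyond the scatter. Trifluoromethyl, like methyl, brings several heavy atoms to that carbon, and the step expected from it is estimated as a 2.3-fold lower number from compound 3 to compound 4 (0.37 log units; beyond the scatter), smaller and less certain than that guide. Compound 4 is therefore estimated at 110 nM, within 35 nM to 330 nM.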

Compound 4, half-maximal effective concentration: 52.5 nM
Estimate against measurement, compound 4: 2.1-fold (0.32 log units) above; the measured number falls inside the stated range.
By their numbers in this assay, from the lowest: compounds 1 and 4 (each within the scatter of the next); then compounds 3 and 2 (each within the scatter of the next).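

In this assay the carbon ortho to a large group clearly responds to its substituent: trifluoromethyl lowers the number against fluoro (a 4.9-fold lower number from compound 3 to compound 4 (0.69 log units; beyond the scatter)) and against hydrogen (a 5.5-fold lower number from compound 2 to compound 4 (0.74 log units; beyond the scatter)). The lower number seen earlier only with methyl therefore now appears with a second group, and the two groups cannot be told apart (a 1.1-fold higher number from compound 1 to compound 4 (0.05 log units; within the scatter)). Nothing measured here explains this shared result. Going by these compounds, whether chloro, methoxy or an amine on this carbon would match them stays open. So does the outcome with a longer chain such as ethyl.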